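Weak cytotoxicity series: swapping the amine on the shared core

A few compounds are considered here, and "the series" means these few. Any claim that something is new, unique, unknown or untested is made for them only; others in the source may bear on it.

Values in a functional assay on KB cells (Homo sapiens) for cytotoxicity, read by MTT assay, with a stated time of 72 h; on this read-out higher numbers stand for weaker inhibition and lower numbers for stronger inhibition:
- compound 1 `O=S(=O)(c1ccccc1)c1nc2ccccc2nc1N1CCc2ccccc2C1` gives 26300 nM
- compound 2 `COc1ccc(S(=O)(=O)c2nc3ccccc3nc2N2CCc3ccccc3C2)cc1` gives > 50000 nM (a limit)
- compound 3 `O=S(=O)(c1ccc(F)cc1)c1nc2ccccc2nc1N1CCc2ccccc2C1` gives 35400 nM

Compound 2 is the starting point here, and it has no exact number. Its > 50000 nM is a limit of the assay: the limit of > 50000 nM in this assay, at which 1 of the 3 values shown sits.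

The next compound is compound 4 `COc1ccc(S(=O)(=O)c2nc3ccccc3nc2N2CCC(O)CC2)cc1`, which keeps the methoxy group of compound 2 and changes the amine: 4-hydroxypiperidin-1-yl in place of 1,2,3,4-tetrahydroisoquinolin-2-yl on an aromatic carbon. In words, 4-hydroxypiperidin-1-yl takes the place of 1,2,3,4-tetrahydroisoquinolin-2-yl.

Going by the values given here, no measured step changes this group. The three available steps all concern the other aromatic ring: an at least 1.9-fold higher number from compound 1 to compound 2 (0.27 log units; that floor lies within the scatter), a 1.3-fold higher number from compound 1 to compound 3 (0.13 log units; within the scatter) and an at least 1.4-fold lower number from compound 2 to compound 3 (0.14 log units; that floor lies within the scatter). All three lie within the scatter, so they give only indirect guidance, and they set neither a size nor a direction for the new step.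

Among the compounds with values here, the only exact values are those of compound 1 at 26300 nM and compound 3 at 35400 nM, and they show weak inhibition in this assay. On that basis, no step beyond the scatter is expected, and a further limit is a real possibility. The expected change is an at least 1.2-fold lower number from compound 2 to compound 4 (0.09 log units; that floor lies within the scatter). For compound 4 the estimated value is 40000 nM, with an expected range of 15000 nM to 100000 nM.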

Compound 4, half-maximal inhibitory concentration: 8060 nM
Beside the measured number, compound 4's estimate is 5.0-fold (0.70 log units) above it, outside the stated range (below it).
By their numbers in this assay, from the lowest: compound 4; then compounds 1 and 3 (each within the scatter of the next). At a limit, above all of these: compound 2.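

In this assay, replacing 1,2,3,4-tetrahydroisoquinolin-2-yl with 4-hydroxypiperidin-1-yl gives an at least 6.2-fold lower number from compound 2 to compound 4 (0.79 log units; beyond the scatter), the only step shown that lies beyond the scatter, while the three steps on the other aromatic ring all stay within it. Going by these compounds alone, the aromatic carbon next to the ring nitrogen is therefore a place where a change of amine, with the methoxy group kept, can move this read-out by more than the scatter, something the earlier compounds could not show. Compound 2 stands at a limit and not at an exact number, so the step gives a floor and not a full size: the limit of > 50000 nM in this assay, at which 1 of the 4 values shown sits.

The change removes the fused aromatic ring and adds the hydroxyl group in a single step, so the compounds shown do not separate the two, and a plain piperidine or a morpholine at this place would bear on that question. Going by these compounds, it also remains open whether 4-hydroxypiperidin-1-yl acts in the same way with hydrogen or fluoro in place of the methoxy group on the other aromatic ring.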